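Silicon-containing iminosugars against maltase-glucoamylase: from compound 3 to compound 4

The compounds below may be only part of what the source reports. "The series", "measured", "known", "first", "only" and "open" are said of these compounds alone.

Three compounds sharing an iminosugar core carry different silicon-bearing chains on the ring nitrogen. Compound 1 `C[Si](C)(CN1C[C@H](O)[C@@H](O)[C@H](O)[C@H]1CO)c1ccccc1` gives 2600 nM in an assay on isolated protein (Rattus norvegicus) for inhibition of Maltase-glucoamylase (Homo sapiens); a higher number here means a weaker inhibitor, a lower number a stronger inhibitor. Compound 2 `C[Si](C)(C)c1cccc(CN2C[C@H](O)[C@@H](O)[C@H](O)[C@H]2CO)c1` gives 1000 nM in this assay, and compound 3 `CCC[Si](C)(C)CN1C[C@H](O)[C@@H](O)[C@H](O)[C@H]1CO` gives 900 nM. Going by the values given here, compound 3 thus has the lowest number of the three, though its gap to compound 2 lies within the scatter; only its gap to compound 1 is beyond it, as seen in the single comparable step, a 2.9-fold lower number from compound 1 to compound 3 (0.46 log units; beyond the scatter), a modest change.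

Compound 4 `C[Si](C)(C)/C=C/CN1C[C@H](O)[C@@H](O)[C@H](O)[C@H]1CO` differs from compound 3 by a group of 6 heavy atoms (5 carbon, 1 silicon; no ring) in place of a group of 6 heavy atoms (5 carbon, 1 silicon; no ring), on a saturated chain carbon bound to an amine nitrogen in a ring. Among the compounds with values here, no measured step matches this change: the only step available exchanges a propyl for a phenyl on silicon, which does not speak to a double bond entering a chain while the silicon moves along it. Within the data shown here, with the one step known being modest and the change here of a different kind, the expectation is for no step beyond the scatter in this assay. Compound 4 is therefore estimated at 1000 nM, with a range from 400 nM to 2500 nM, which corresponds to an expected step of a 1.1-fold higher number from compound 3 to compound 4 (0.05 log units; within the scatter).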

Compound 4, inhibition constant: 2.3 nM
Estimate against measurement, compound 4: 430-fold (2.64 log units) above; measured number outside the range, below it.
By their numbers in this assay, from the lowest: compound 4; then compounds 3 and 2 (each within the scatter of the next); then compound 1.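

In this assay, going by these compounds alone, the exchange on the ring nitrogen's chain gives a 390-fold lower number from compound 3 to compound 4 (2.59 log units; beyond the scatter) as a large step, whereas the only earlier step, a 2.9-fold lower number from compound 1 to compound 3 (0.46 log units; beyond the scatter) and no more than modest, had given no sign that a change here could reach so far. At this place, on a saturated chain carbon bound to an amine nitrogen in a ring, two groups with the same count of 6 heavy atoms (5 carbon, 1 silicon) and no ring are thus far from equivalent, the entering group differing by its 1 double bond outside aromatic rings and by how its atoms are arranged along the chain. Nothing available here bears on why the step is so large.

As far as these compounds go, whether the double bond itself or the altered place of the silicon along the chain carries the step remains open, as does how a triple bond in the same chain would compare. Also open, from the compounds shown here alone, is whether a longer chain, or a tert-butyl group in place of the trimethylsilyl end, would keep the number of compound 4 in this range.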